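Compound 3 to compound 4 on the carbonyl carbon

The source may report more compounds than this note shows. Statements on the series, on what has been measured and on what is new or still open speak of the compounds shown alone.

In a physicochemical assay for lipophilicity, read by HPLC, measured as chromatographic lipophilicity, at pH 7.4 (on this read-out lower numbers stand for lower lipophilicity and higher numbers for higher lipophilicity), compound 3 `CC(C)(CN)C(=O)N1N=CCC1c1ccccc1` reads 1.4 and is the lowest of the three numbers. Compound 1 `O=C(C1CCCC1)N1N=CCC1c1ccccc1` stands at 5.4 and compound 2 `O=C(C1CCCCC1)N1N=CCC1c1ccccc1` at 5.9 on the same scale.

The move to compound 4 `O=C(C1CCOCC1)N1N=CCC1c1ccccc1` is oxan-4-yl in place of 1-(aminomethyl)-1-methylethyl on a carbonyl carbon and puts oxan-4-yl in place of 1-(aminomethyl)-1-methylethyl on a carbonyl carbon. Both a number 4.00 log units lower from compound 1 to compound 3 (beyond the scatter) and a number 4.50 log units lower from compound 2 to compound 3 (beyond the scatter) are large and lead to the chain that now leaves. Within the data shown here, the step of a number 0.50 log units higher from compound 1 to compound 2 (beyond the scatter) is modest and is the only measured change between two rings. Oxan-4-yl has not been measured in this series, so how far the number climbs toward compound 2 at 5.9 remains open, and a place partway up is expected. The expected step is a number 2.30 log units higher from compound 3 to compound 4 (beyond the scatter) and it is estimated as large and upward. In this assay compound 4 is estimated at 3.7 with 3 to 4.4 as the expected range.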

Compound 4, distribution coefficient: 3.1
Estimate against measurement, compound 4: 0.60 log units above; measured number inside the range.
By their numbers in this assay, from the lowest: compound 3; then compound 4; then compound 1; then compound 2.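

In this assay, a change from one ring to another at this carbonyl carbon proves able to move the number by far more than the earlier cyclopentyl-to-cyclohexyl change (a number 0.50 log units higher from compound 1 to compound 2 (beyond the scatter)), as oxan-4-yl sits well under both carbocyclic rings (a number 2.80 log units lower from compound 2 to compound 4 (beyond the scatter); a number 2.30 log units lower from compound 1 to compound 4 (beyond the scatter)). Compound 4 and compound 2 both carry a six-membered ring here, and the ring oxygen of oxan-4-yl is what separates them. The 1-(aminomethyl)-1-methylethyl chain still gives the lower number (a number 1.70 log units higher from compound 3 to compound 4 (beyond the scatter)). No supporting data bear on why the number falls where it does.

Open, from the compounds shown here alone, is how a piperidin-4-yl ring, with an amine in the ring, or a smaller oxolan-3-yl ring would read at this position. Also open, going by these compounds, is how much of the low number of compound 3 belongs to its primary amine rather than its branched chain, which a simple 2,2-dimethylpropyl group could help to separate.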